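The source may hold more compounds than are shown below. What is called first, only, known or untested is meant among the compounds shown, and "the series" means these compounds.

Compound 1 `C=C1CC[C@@H]2[C@](C)(CNCc3ccccc3)[C@H](O)CC[C@@]2(C)[C@@H]1/C=C/C1=CCOC1=O`: 960 nM
Compound 2 `C=C1CC[C@@H]2[C@](C)(CNCc3ccc(F)cc3)[C@H](O)CC[C@@]2(C)[C@@H]1/C=C/C1=CCOC1=O`: 350 nM
Compound 3 `C=C1CC[C@@H]2[C@](C)(CNCc3ccc(C#N)cc3)[C@H](O)CC[C@@]2(C)[C@@H]1/C=C/C1=CCOC1=O`: 1130 nM

All three were tested in a functional assay on BMMC cells (Mus musculus, strain C57BL/6) for inhibition, with stated times of 5 days and 48 h; a lower number here means a stronger inhibitor, a higher number a weaker inhibitor. Compound 3 gives the highest of the three numbers; it sits close to compound 1, with a 1.2-fold higher number from compound 1 to compound 3 (0.07 log units; within the scatter), whereas compound 2 lies further off, with a 3.2-fold higher number from compound 2 to compound 3 (0.51 log units; beyond the scatter). Compound 4 `C=C1CC[C@@H]2[C@](C)(CNCc3ccc4c(c3)CC=N4)[C@H](O)CC[C@@]2(C)[C@@H]1/C=C/C1=CCOC1=O` is not yet measured. It differs from compound 3 in one place: a group of 9 heavy atoms (8 carbon, 1 nitrogen; one five-membered non-aromatic ring with 1 hetero atom, one six-membered aromatic ring of carbon only) in place of a group of 8 heavy atoms (7 carbon, 1 nitrogen; one six-membered aromatic ring of carbon only), on a saturated chain carbon bound to an amine nitrogen. For the measured compounds named here, the steps that bear on this are the changes made at the same aromatic carbon, a 1.2-fold higher number from compound 1 to compound 3 (0.07 log units; within the scatter) and a 3.2-fold higher number from compound 2 to compound 3 (0.51 log units; beyond the scatter), together with a 2.7-fold lower number from compound 1 to compound 2 (0.44 log units; beyond the scatter); all are modest, and none involves a group of this kind. A step of modest size in either direction, or none beyond the scatter, is therefore expected in this assay. Compound 4 is estimated to give 800 nM, within 250 nM to 2500 nM, meaning an expected 1.4-fold lower number from compound 3 to compound 4 (0.15 log units; within the scatter).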

Compound 4, half-maximal inhibitory concentration: 550 nM
Beside the measured number, compound 4's estimate is 1.5-fold (0.16 log units) above it; measured number inside the range.
By their numbers in this assay, from the lowest: compounds 2, 4, 1 and 3 (each within the scatter of the next, the first and the last beyond it).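

At this saturated chain carbon bound to an amine nitrogen, this assay tolerates a group with a five-membered non-aromatic ring in addition to the six-membered aromatic ring, and its exchange for 4-cyanophenyl gives a 2.1-fold lower number from compound 3 to compound 4 (0.31 log units; beyond the scatter). Against the other two groups the new group stands within the scatter, with a 1.6-fold higher number from compound 2 to compound 4 (0.20 log units; within the scatter) and a 1.7-fold lower number from compound 1 to compound 4 (0.24 log units; within the scatter), so the second ring brings no measurable gain over either. Nothing given here accounts for these steps.

It remains open whether the ring nitrogen matters, since a five-membered ring of carbon only is not among these compounds. From the compounds shown here alone, how a carboxylic acid or an amine on the aromatic ring would fare also stays open.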